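Replacing the benzofuran amide with a pyridine amide

The compounds below may be only part of what the source reports. "The series", "measured", "known", "first", "only" and "open" are said of these compounds alone.

Among the compounds with values here, compound 1 `COc1ccc(Cl)cc1N1CCN(CCNC(=O)c2cc3ccccc3o2)CC1` gives 2340 nM in a functional assay for antagonist activity at Adrenergic receptor alpha-1 (Rattus norvegicus) (a higher number here means weaker binding, a lower number tighter binding), the highest of the two numbers so far; compound 2 `COc1ccc(Cl)cc1N1CCN(CCNC(=O)c2cc3ccccc3oc2=O)CC1` gives 49 nM in this assay. Compound 3 `COc1ccc(Cl)cc1N1CCN(CCNC(=O)c2ccncc2)CC1` differs from compound 1 by pyridin-4-yl in place of 1-benzofuran-2-yl on a carbonyl carbon. Within the data shown here, no measured pair shows this kind of change, so the expected step from compound 1 to compound 3 is set at a 1.3-fold lower number from compound 1 to compound 3 (0.11 log units; within the scatter), which is not beyond the scatter in either direction. On that basis compound 3 is estimated to give 1800 nM in this assay, within a range from 400 nM to 8000 nM.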

Compound 3, dissociation constant: 66.1 nM
Compound 3: middle estimate off by 27-fold (1.44 log units), on the high side; the whole stated range lies above it.
By their numbers in this assay, from the lowest: compounds 2 and 3 (each within the scatter of the next); then compound 1.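

At this position the group on the carbonyl carbon matters greatly in this assay: pyridin-4-yl in place of 1-benzofuran-2-yl gives a 35-fold lower number from compound 1 to compound 3 (1.55 log units; beyond the scatter). A single six-membered aromatic ring is therefore enough here, and compound 3 lies within the scatter of compound 2, whose group on the carbonyl carbon is larger. No measurement at hand accounts for this gain. On these data alone, whether the ring nitrogen or its place in the ring matters remains open. Plain phenyl, pyridin-3-yl or pyridin-2-yl on the same carbonyl carbon would test this.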